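The source may hold more compounds than are shown below. What is called first, only, known or untested is meant among the compounds shown, and "the series" means these compounds.

Working notes on the series. Compound 1 `CC[C@@H](Nc1c(Nc2cccc(C(=O)N(C)C)c2O)c(=O)c1=O)c1cc(C(C)C)co1` gives 3 nM in an assay on CHO cells for displacement of a labelled ligand from C-X-C chemokine receptor type 1 (Homo sapiens) (on this read-out lower numbers stand for stronger inhibition and higher numbers for weaker inhibition), the lowest number among the three measured. Compound 2 `CC[C@@H](Nc1c(Nc2cccc(C(=O)N(C)C)c2O)c(=O)c1=O)c1cc(C2CCCC2)co1`, with cyclopentyl in place of isopropyl on an aromatic carbon, gives 53 nM in this assay; the step is an 18-fold higher number from compound 1 to compound 2 (1.25 log units; beyond the scatter). Compound 3 `CC(C)c1coc([C@H](Nc2c(Nc3cccc(C(=O)N(C)C)c3O)c(=O)c2=O)C(C)C)c1`, with methyl in place of hydrogen on a saturated chain carbon bound to two saturated chain carbons, gives 11 nM in this assay; the step is a 3.7-fold higher number from compound 1 to compound 3 (0.56 log units; beyond the scatter). Compound 3 thus stands second highest of the three numbers: compound 1 sits below it by a step beyond the scatter, and compound 2 sits above it by a gap that the two values also place beyond the scatter.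

Compound 4 `CC(C)c1coc([C@H](Nc2c(Nc3cccc(C(=O)N(C)C)c3O)c(=O)c2=O)C(C)(C)C)c1` differs from compound 3 by methyl in place of hydrogen on a saturated chain carbon bound to three saturated chain carbons. The step bearing on it most directly is a 3.7-fold higher number from compound 1 to compound 3 (0.56 log units; beyond the scatter), which put methyl in place of hydrogen on the same chain and raised the number. The larger move an 18-fold higher number from compound 1 to compound 2 (1.25 log units; beyond the scatter) also went upward when a group grew, though on an aromatic carbon. A further rise in this assay is therefore expected for compound 4, of modest size, possibly larger. Compound 4 is expected to give 40 nM, with a range of 12 nM to 140 nM. The expected step is a 3.6-fold higher number from compound 3 to compound 4 (0.56 log units; beyond the scatter).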

Compound 4, inhibition constant: 14 nM
Estimate against measurement, compound 4: 2.9-fold (0.46 log units) above, within the range that was stated.
By their numbers in this assay, from the lowest: compound 1; then compounds 3 and 4 (each within the scatter of the next); then compound 2.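

Isopropyl to tert-butyl on this saturated chain carbon gives a 1.3-fold higher number from compound 3 to compound 4 (0.10 log units; within the scatter) in this assay, so compound 3 and compound 4 cannot be told apart, and this methyl in place of hydrogen does not repeat the earlier step of a 3.7-fold higher number from compound 1 to compound 3 (0.56 log units; beyond the scatter). Tert-butyl still stands clear of the ethyl of compound 1, with a 4.7-fold higher number from compound 1 to compound 4 (0.67 log units; beyond the scatter), so among the three groups shown on this carbon, ethyl alone separates from the others, while isopropyl and tert-butyl read alike, and the number does not climb with each added methyl. No measurement accompanies these values that would account for this levelling.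

Open, on these data alone, is how a cyclopropyl group, a longer straight chain such as n-butyl, or a methoxymethyl group on this carbon would read, and whether any of them returns to the level of compound 1. Also open, as far as these compounds go, is whether the step seen on the aromatic carbon, an 18-fold higher number from compound 1 to compound 2 (1.25 log units; beyond the scatter), keeps its size when tert-butyl stands on the chain carbon.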